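Replacing the amide on the core of compound 1

The source may hold more compounds than are shown below. What is called first, only, known or untested is meant among the compounds shown, and "the series" means these compounds.

Compound 1 `O=C(Nc1cnc(NCc2c(F)ccc3c2CCO3)n2cnnc12)c1cccnc1` is the least soluble of the three compounds measured here. In a physicochemical assay for solubility, read by LC-MS, in phosphate buffer, with a stated time of 24 h, at pH 7.4 (on this read-out lower numbers stand for lower solubility and higher numbers for higher solubility), compound 1 gives 12000 nM, while compound 2 `Cc1nc(C(=O)N(C)C)ccc1-c1cnc(NCc2c(F)ccc3c2CCO3)c2cn[nH]c(=O)c12` gives 403000 nM and compound 3 `CN(C)Cc1ccc(C(=O)Nc2cnc(NCc3c(F)ccc4c3CCO4)n3cnnc23)cc1` gives 520000 nM. For the measured compounds named here, the one step measured between two compounds that differ in one place, a 43-fold higher number from compound 1 to compound 3 (1.64 log units; beyond the scatter), introduces a basic amine-bearing group and does not match the change examined now. Compound 4 `CN(C(=O)c1ccccc1)c1cnc(NCc2c(F)ccc3c2CCO3)n2cnnc12` differs from compound 1 in that (benzoyl(methyl)amino in place of ((pyridin-3-yl)carbonyl)amino on an aromatic carbon). Going by the values given here, no measured step bears directly on this exchange: the hydrogen-bond donor is removed and the ring nitrogen is lost, and the data give no precedent for either. Compound 4 is therefore expected to stay close to compound 1 in this assay, with a step of a 2.5-fold higher number from compound 1 to compound 4 (0.40 log units; beyond the scatter) that may sit only just beyond the scatter. The estimate for compound 4 is 30000 nM, within a range from 6000 nM to 150000 nM.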

Compound 4, solubility: 280000 nM
Estimate against measurement, compound 4: 9.3-fold (0.97 log units) below; measured number above the stated range.
By their numbers in this assay, from the lowest: compound 1; then compounds 4, 2 and 3 (each within the scatter of the next).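

In this assay, the exchange at this aromatic carbon gives a 23-fold higher number from compound 1 to compound 4 (1.37 log units; beyond the scatter) and so shows that a large step is possible here without any amine-bearing group, unlike the earlier 43-fold higher number from compound 1 to compound 3 (1.64 log units; beyond the scatter), where the entering group carries a dimethylamino group. The new exchange alters two features at once, putting a methyl in place of the amide hydrogen and a ring of carbon only in place of pyridin-3-yl, so this step cannot be divided between them. No measurement at hand gives a cause for the step.

The compounds shown leave open which of the two features carries the step, which a plain benzoylamino group and a methylated (pyridin-3-yl)carbonylamino group could separate. Also open, from the compounds shown here alone, is how a larger group on that nitrogen, such as an ethyl, would read.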